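Pentan-3-yl for Isobutyl on a Fast-Cleared Core

The source may hold more compounds than are shown below. What is called first, only, known or untested is meant among the compounds shown, and "the series" means these compounds.

Of the compounds shown here, three sharing one core have been measured in an in vitro ADME assay on microsomes from liver (Homo sapiens) for metabolic stability; a lower number here means slower removal, a higher number faster removal of the compound. Compound 1 `CC[C@H](C)[C@@H]1C(=O)N[C@H](C2Cc3ccccc3C2)C(=O)N1[C@@H](C(=O)N(C)C)c1ccc(C)[n+]([O-])c1` gives 1 mL.min-1.g-1 in this assay, and compound 2 `CC[C@H](C)[C@@H]1C(=O)N[C@H](C2Cc3ccccc3C2)C(=O)N1[C@@H](C(=O)NC)c1cc(C)cnc1C` gives 3 mL.min-1.g-1. Compound 3 `Cc1ccc([C@H](C(=O)N(C)C)N2C(=O)[C@@H](C3Cc4ccccc4C3)NC(=O)[C@H]2CC(C)C)cn1` gives 11000 mL.min-1.g-1, the highest of the three numbers; its gaps to compound 2, the nearest, and to compound 1, the furthest, both lie well beyond the usual scatter, so compound 3 is removed far faster than either.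

Compound 4 `CCC(CC)[C@@H]1C(=O)N[C@H](C2Cc3ccccc3C2)C(=O)N1[C@@H](C(=O)N(C)C)c1ccc(C)nc1` has not been measured yet. It differs from compound 3 in one place: pentan-3-yl in place of isobutyl on a saturated ring carbon. Among the compounds with values here, no measured pair in this set shows what such a swap of one small alkyl chain for another does to clearance, so the expectation rests on compound 3 alone. A change this modest is expected to move the number little, and the step of a 1.4-fold lower number from compound 3 to compound 4 (0.14 log units; within the scatter) is expected to stay within the scatter. Compound 4 is therefore estimated at 8000 mL.min-1.g-1 in this assay, with a range from 2000 mL.min-1.g-1 to 30000 mL.min-1.g-1.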

Compound 4, intrinsic clearance in microsomes: 11 mL.min-1.g-1
Beside the measured number, compound 4's estimate is 730-fold (2.86 log units) above it, and the stated range ends above it.
By their numbers in this assay, from the lowest: compound 1; then compound 2; then compound 4; then compound 3.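

On a saturated ring carbon next to the ring nitrogen, replacing isobutyl with pentan-3-yl adds a single carbon and no ring, hydrogen-bond donor, hydrogen-bond acceptor or charge, yet it gives a 1000-fold lower number from compound 3 to compound 4 (3.00 log units; beyond the scatter) in this assay. Within the data shown here, this is the first pair in the set to isolate this position, and it shows that a swap of one small alkyl chain for another at this ring carbon can separate very fast removal from slow removal. Nothing available here explains why the number falls so far.

On these data alone, it remains open whether cyclopentyl or a straight pentyl chain on this ring carbon would also give a number far below that of compound 3. As far as these compounds go, it is equally open whether pentan-3-yl would have so large an effect with other groups elsewhere on the shared core.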